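The compounds below may be only part of what the source reports. "The series", "measured", "known", "first", "only" and "open" are said of these compounds alone.

Measured compounds:
Compound 1, `C[C@@H](Nc1c(C(=O)NCc2ccc(F)cc2)nc(Br)c2cccnc12)c1ccccc1` — in a functional assay on HCT-116 cells (Homo sapiens) for cytotoxicity, read by MTT assay, with a stated time of 72 h (a lower number here means a stronger inhibitor, a higher number a weaker inhibitor), compound 1 gives > 20000 nM, a limit of the assay, not a number.
Compound 2, `NCCCNc1c(C(=O)NCc2ccc(F)cc2)nc(Br)c2cccnc12` — in this assay compound 2 gives 18000 nM.
Compound 3, `CC(C)(C)OC(=O)N1CCN(c2c(C(=O)NCc3ccc(F)cc3)nc(Br)c3cccnc23)CC1` — in this assay compound 3 gives > 10000 nM, again a limit of the assay, not a number.

For the measured compounds named here, compound 2 holds the only number among the three values; the other two are limits. Compound 1 sits at the limit of > 20000 nM in this assay, at which 1 of the 3 values shown sits. Going by the values given here, the one measured step, an at least 1.1-fold lower number from compound 1 to compound 2 (0.04 log units; that floor lies within the scatter), rests on that limit and so gives only a floor, with nothing to say on how large the true change is.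

Compound 4, `NCCCCCCNc1c(C(=O)NCc2ccc(F)cc2)nc(Br)c2cccnc12`, differs from compound 2 as 3-aminopropyl in place of amino on a saturated chain carbon, three bonds along the chain from a nitrogen on an aromatic ring. Among the compounds with values here, no measured step bears on a lengthening of this chain: the only known step exchanges what sits on the nitrogen on the aromatic ring, and leaves the chain length untouched. With weak activity throughout and no guide from the measured steps, the expectation for compound 4 in this assay is no step beyond the scatter, and a 1.2-fold lower number from compound 2 to compound 4 (0.08 log units; within the scatter) is the estimated change. Compound 4 is expected at 15000 nM, with a range of 5000 nM to 40000 nM, and a fair chance that this assay reports only a limit.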

Compound 4, half-maximal inhibitory concentration: > 10000 nM
Compound 4 ended at the assay's limit; the forecaster's own chance of this, stated with the estimate: 40%; the middle value does not contradict the limit.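

In this assay compound 4 gives > 10000 nM, a limit of the assay and not a number. Its steps from compound 2 and from compound 1 cannot be read. On these data alone, whether going from 3-aminopropyl to 6-aminohexyl changes the activity at all remains open.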